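Swapping an aromatic amide group for isopropyl

The source may report more compounds than this note shows. Statements on the series, on what has been measured and on what is new or still open speak of the compounds shown alone.

Values so far in an in vitro ADME assay on microsomes from liver (Homo sapiens) for pharmacokinetics, read by LC-MS, with a stated time of 10 min, tested at 1 uM; a higher number here means faster removal of the compound, a lower number slower removal
Compound 1 `CN1C[C@H](C(=O)Nc2ccc(C(F)(F)F)cc2)[C@@H](c2ccc(/C=C/C(=O)Nc3ccccc3N)cc2)C1` (measured 6 mL/min/kg)
Compound 2 `CN1C[C@H](C(=O)Nc2ccc(Cl)cc2F)[C@@H](c2ccc(/C=C/C(=O)Nc3ccccc3N)cc2)C1` (measured 11 mL/min/kg)
Compound 3 `CN1C[C@H](C(=O)Nc2ccc(Cl)cn2)[C@@H](c2ccc(/C=C/C(=O)Nc3ccccc3N)cc2)C1` (measured 13 mL/min/kg)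

Compound 3 stands clear of compound 1 alone, as the record shows (a 2.2-fold higher number from compound 1 to compound 3 (0.34 log units; beyond the scatter)). The other comparison (a 1.2-fold higher number from compound 2 to compound 3 (0.07 log units; within the scatter)) leaves compound 3 level with compound 2.

The next compound, compound 4 `CC(C)NC(=O)[C@H]1CN(C)C[C@@H]1c1ccc(/C=C/C(=O)Nc2ccccc2N)cc1`, keeps the shared core and alters only the amide, with isopropyl in place of 5-chloropyridin-2-yl on an amide-type nitrogen.

The measured steps bear on this only in part. Each swaps one aromatic group for another on an amide-type nitrogen, and all are small. The remaining one (a 1.8-fold higher number from compound 1 to compound 2 (0.26 log units; within the scatter)) also stays within the scatter, and the largest, seen above between compound 1 and compound 3, is modest. Going by the values given here, none replaces an aromatic ring with a small open chain such as isopropyl, so the data hold no direct precedent and the range must stay wide. The expected step in this assay is therefore (a 1.3-fold lower number from compound 3 to compound 4 (0.11 log units; within the scatter)) no larger than the scatter, with no firm direction. Compound 4 is estimated at 10 mL/min/kg (expected range 5 mL/min/kg to 20 mL/min/kg).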

Compound 4, clearance: 8 mL/min/kg
Beside the measured number, compound 4's estimate is 1.3-fold (0.10 log units) above it, within the range that was stated.
By their numbers in this assay, from the lowest: compounds 1, 4, 2 and 3 (each within the scatter of the next, the first and the last beyond it).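

Until now, this amide-type nitrogen had carried only aromatic groups, so compound 4 adds a new kind of change: the ring is gone, and an open isopropyl group stands in its place. In this assay, this larger change in shape of the substituent stays within the scatter against all three aromatic compounds (a 1.6-fold lower number from compound 3 to compound 4 (0.21 log units; within the scatter)) and (a 1.4-fold lower number from compound 2 to compound 4 (0.14 log units; within the scatter)) and (a 1.3-fold higher number from compound 1 to compound 4 (0.12 log units; within the scatter)), so an aromatic ring at this position is not needed for a number in this range, even though compound 1 and compound 3 themselves stand apart (a 2.2-fold higher number from compound 1 to compound 3 (0.34 log units; beyond the scatter)). Nothing available here explains why the number holds level across these groups.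

Going by these compounds, the four compounds cover only aromatic groups and one small branched chain, so it remains open how this assay would respond to a longer chain such as n-butyl, or to a chain carrying an amine or a carboxylic acid at this position. Also open, on these data alone, is whether the level reading would hold for a saturated ring such as cyclohexyl, which would stand closer in size to the aromatic groups while having no aromatic ring.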